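This account rests on a few compounds, and the source may have more. Where it says the series, first, only, none or still open, it means among the compounds named here.

Measured compounds:
Compound 1 `CN1CCN(c2ccc(Nc3nc(-c4cccc(NC(=O)c5cccc(F)c5)c4)sc3C(N)=O)cc2)CC1`: "not determined" (no result reported)
Compound 2 `CN1CCN(c2ccc(Nc3nc(-c4cccc(NC(=O)c5ccc(F)c(Cl)c5)c4)sc3C(N)=O)cc2)CC1`: 6230 nM

Within the data shown here, in a functional assay on Raji cells (Homo sapiens) for antiproliferative activity, read by CCK-8 assay, with a stated time of 72 h (a lower number here means a stronger inhibitor, a higher number a weaker inhibitor), compound 2 gives 6230 nM, the only number in this small set. Compound 1 is recorded in this assay as "not determined" (no result reported), so no comparison between the two measured compounds can be drawn, and compound 2 stands alone as a weak inhibitor. Compound 3 `CN1CCN(c2ccc(Nc3nc(-c4cccc(NC(=O)c5ccco5)c4)sc3C(N)=O)cc2)CC1` has not yet been measured in this assay. It differs from compound 2 by furan-2-yl in place of 3-chloro-4-fluorophenyl on a carbonyl carbon. Among the measured compounds shown here, no measured step of this kind exists here, so any expectation rests on the single value of compound 2. For compound 3 the step of a 1.6-fold higher number from compound 2 to compound 3 (0.21 log units; within the scatter) is expected to be modest, likely within the scatter or slightly toward weaker inhibition. Compound 3 is therefore estimated at 10000 nM, with a range from 2500 nM to 40000 nM.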

Compound 3, half-maximal inhibitory concentration: 37400 nM
Beside the measured number, compound 3's estimate is 3.7-fold (0.57 log units) below it; the measured number falls inside the stated range.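

In this assay, the group on the carbonyl carbon proves able to move the read-out: furan-2-yl in place of 3-chloro-4-fluorophenyl gives a 6.0-fold higher number from compound 2 to compound 3 (0.78 log units; beyond the scatter), a change toward weaker inhibition. Until now, compound 2 stood alone and gave no sense of how this position responds, whereas this pair shows that the amide substituent is not interchangeable in this cell assay. Nothing available accounts for the shift.

The step swaps the whole ring, so it cannot show whether the loss follows from the change of ring or from the loss of the chlorine and fluorine substituents, and compound 1 offers no number to help separate them. Going by these compounds, it also remains open whether a plain phenyl, a thiophen-2-yl or a pyridin-3-yl on that carbonyl carbon would read closer to compound 2 or to compound 3.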